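A few compounds are considered here, and "the series" means these few. Any claim that something is new, unique, unknown or untested is made for them only; others in the source may bear on it.

Compound 1 `Cc1cc(NC(=O)c2cc([N+](=O)[O-])ccc2Cl)cc(-c2nc3ccccc3s2)c1O`: in an ADME assay on HEK293 cells (Homo sapiens) for cytotoxicity, with a stated time of 72 h (a higher number here means that more compound is needed for the effect, a lower number that less compound is needed), compound 1 reaches only the limit > 25000 nM.
Compound 2 `O=C(Nc1cc(-c2nc3ccccc3s2)ccc1Cl)c1cc([N+](=O)[O-])ccc1Cl`: in this assay compound 2 likewise reaches only the limit > 25000 nM.
Compound 3 `O=C(Nc1nc(-c2cccc(F)c2)cs1)c1cc([N+](=O)[O-])ccc1Cl`: in this assay compound 3 gives 8700 nM.

Compound 2 therefore stands at the top of what the assay reports, a limit rather than a number, and it shares that position with compound 1: the limit of > 25000 nM in this assay, at which 2 of the 3 values shown sit. Only compound 3 returns a measured value.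

The next compound, compound 4 `COc1ccc(-c2nc3ccccc3s2)cc1NC(=O)c1cc([N+](=O)[O-])ccc1Cl`, is reached from compound 2 by a single change: methoxy in place of chloro on an aromatic carbon. For the measured compounds named here, no pair of measured compounds differs in one place, so there is no measured step to lean on. The expectation for this assay is a step of no size beyond the scatter, with compound 4 staying at the limit as compound 2 does.

Compound 4 is thus expected to give 25000 nM, with a range from 8000 nM to 60000 nM. The step that this estimate implies, a number no higher from compound 2 to compound 4 (the limit leaves the size open), is expected to amount to nothing beyond the scatter.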

Compound 4, half-maximal effective concentration: > 25000 nM
Compound 4 ended at the assay's limit; the forecaster's own chance of this, stated with the estimate: 60%; the middle value lies on the limit itself.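

In this assay compound 2 and compound 4 both give a limit rather than a number, so no step can be read between them: the limit of > 25000 nM in this assay, at which 3 of the 4 values shown sit.

The compounds shown leave open whether methoxy in place of chloro on an aromatic carbon shifts the read-out at all.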